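A few compounds are considered here, and "the series" means these few. Any claim that something is new, unique, unknown or untested is made for them only; others in the source may bear on it.

Measured so far:
Compound 1, `O=C(CSCCc1ccccc1)C(F)(F)F`: 6.46 nM
Compound 2, `CCCCCCCCCCCCS(=O)(=O)CC(O)(O)C(F)(F)F`: 0.398 nM
Compound 3, `CCCCCCCC[S+]([O-])CC(O)(O)C(F)(F)F`: 0.603 nM

These values come from an assay on isolated protein for inhibition of liver carboxylesterase 1 (Homo sapiens), with a stated time of 24 h; a higher number here means a weaker inhibitor, a lower number a stronger inhibitor. Compound 2 gives the lowest number of the three, though compound 3 lies within the usual scatter of it, so the two cannot be ranked against each other; compound 1 sits well beyond the scatter. The next compound, compound 4 `CCCCCCS(=O)(=O)CC(O)(O)C(F)(F)F`, has not been measured yet. It differs from compound 2 in one place: hydrogen in place of hexyl on a saturated chain carbon, six bonds along the chain from a sulfonyl sulfur. Going by the values given here, no step between two measured compounds isolates this change, so the expectation rests only on the spread of numbers already seen. A weaker inhibitor is expected, with the step from compound 2 to compound 4 estimated at a 5.0-fold higher number from compound 2 to compound 4 (0.70 log units; beyond the scatter), beyond the scatter. Compound 4 is therefore expected to give 2 nM, in the range 0.5 nM to 8 nM.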

Compound 4, inhibition constant: 0.708 nM
For compound 4 the middle estimate is 2.8-fold (0.45 log units) above the measured one, and the stated range covers the measured number.
By their numbers in this assay, from the lowest: compounds 2, 3 and 4 (each within the scatter of the next); then compound 1.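

In this assay, hydrogen in place of hexyl on a saturated chain carbon, six bonds along the chain from a sulfonyl sulfur, gives a 1.8-fold higher number from compound 2 to compound 4 (0.25 log units; within the scatter) and so leaves a difference that cannot be told from scatter. Between these two compounds, then, the outer six carbons of the chain can go without a measurable loss of inhibition. Nothing available here explains why the two compounds read alike.

Still open, from the compounds shown here alone, is how a much shorter chain, such as methyl or ethyl, on the sulfonyl sulfur would read. So is the effect of an amine or a carboxylic acid at the end of the chain.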